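The source may hold more compounds than are shown below. What is called first, only, known or untested is meant among the compounds shown, and "the series" means these compounds.

Measured so far in a physicochemical assay for lipophilicity, read by HPLC; on this read-out higher numbers stand for higher lipophilicity and lower numbers for lower lipophilicity: compound 1 `CCn1c(-c2cnc(C)nc2)nc2c(N[C@H]3CCN(C(=O)N4CC(OC)C4)C3)ncnc21` gives 0.7; compound 2 `CCn1c(-c2cnc(C)nc2)nc2c(N[C@H]3CCN(C(=O)c4cocn4)C3)ncnc21` gives 0.6; compound 3 `CCn1c(-c2ccc(C(F)(F)F)nc2)nc2c(O[C@H]3CCN(C(=O)N4CC(OC)C4)C3)ncnc21` gives 2.1.

Compound 2 differs from compound 1 by one change, (1,3-oxazol-4-yl in place of 3-methoxyazetidin-1-yl on a carbonyl carbon). In this assay that change made a step of a number 0.10 log units lower from compound 1 to compound 2 (within the scatter). Compound 3 carries a different core; how it differs from compound 1 is not broken down here, and its value stands well apart from those of compound 1 and compound 2.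

Compound 4 `CCn1c(-c2ccc(C(F)(F)F)nc2)nc2c(O[C@H]3CCN(C(=O)c4cocn4)C3)ncnc21` is not yet measured. It differs from compound 3 by 1,3-oxazol-4-yl in place of 3-methoxyazetidin-1-yl on a carbonyl carbon, the same change at the same kind of place as from compound 1 to compound 2. Because the earlier step was a number 0.10 log units lower from compound 1 to compound 2 (within the scatter), compound 4 is expected to sit near compound 3, with an estimated step of a number 0.10 log units lower from compound 3 to compound 4 (within the scatter). Compound 4 is therefore estimated at 2 in this assay, between 1.6 and 2.4.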

Compound 4, distribution coefficient: 2
Beside the measured number, compound 4's estimate shows no gap at the digits printed, and the stated range covers the measured number.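

In this assay, putting 1,3-oxazol-4-yl in place of 3-methoxyazetidin-1-yl on a carbonyl carbon gave a number 0.10 log units lower from compound 3 to compound 4 (within the scatter) and had earlier given a number 0.10 log units lower from compound 1 to compound 2 (within the scatter) on the core of compound 1. The two pairs therefore agree, with both steps inside the scatter, so on these two cores the change carries across with the same reading. That rests on two pairs only and does not show that the change would read the same on any other core, and nothing shown here offers a reason for the agreement.

The compounds shown leave open how a step would read with a different group on the same carbonyl carbon. A dimethylamino group or a carboxylic acid-bearing ring in place of 1,3-oxazol-4-yl could give a different answer on either core.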